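Cytotoxicity in liver cells: swapping the aryl group

The compounds below may be only part of what the source reports. "The series", "measured", "known", "first", "only" and "open" are said of these compounds alone.

Measured so far:
- compound 1 `Cc1oc(-c2ccc(Cl)cc2)nc1CN1CCC(C(=O)NCCCN2C[C@H](C)C[C@H](C)C2)CC1`: 11500 nM
- compound 2 `Cc1ccccc1-c1nc(CN2CCC(C(=O)NCCCN3CCCCC3)CC2)c(C)o1`: 18100 nM
- compound 3 `Cc1ccccc1-c1nc(CN2CCC(C(=O)NCCCN3CCCC(C(C)C)C3)CC2)c(C)o1`: 5820 nM

All three compounds were tested in an ADME assay on Huh7.5.1 cells (Homo sapiens) for cytotoxicity, read by ATP content, with a stated time of 48 h; a higher number here means that more compound is tolerated, a lower number that less compound is tolerated. Compound 1 stands second highest of the three numbers; its gap to compound 2 is within the scatter, and so is its gap to compound 3. Within the data shown here, the only step between compounds that differ in one place is a 3.1-fold lower number from compound 2 to compound 3 (0.49 log units; beyond the scatter), which concerns the saturated ring at the far end of the chain and not the aryl group.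

Compound 4 `COc1cccc(Cl)c1-c1nc(CN2CCC(C(=O)NCCCN3C[C@H](C)C[C@H](C)C3)CC2)c(C)o1` has not yet been measured. It differs from compound 1 by 2-chloro-6-methoxyphenyl in place of 4-chlorophenyl on an aromatic carbon. Among the measured compounds shown here, no measured pair changes this aryl group alone, so no step speaks directly to it; compounds 1 and 2 carry different aryl groups and also differ elsewhere, and their values lie within the scatter of each other. The expectation for this assay is therefore no step beyond the scatter, a 1.2-fold lower number from compound 1 to compound 4 (0.06 log units; within the scatter). Compound 4 is estimated at 10000 nM, expected between 4000 nM and 25000 nM.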

Compound 4, half-maximal cytotoxic concentration: 15800 nM
Compound 4: the middle estimate sits 1.6-fold (0.20 log units) below what was measured, and the stated range covers the measured number.
By their numbers in this assay, from the lowest: compounds 3, 1, 4 and 2 (each within the scatter of the next, the first and the last beyond it).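

Changing this aryl group alone gives a step within the scatter in this assay (a 1.4-fold higher number from compound 1 to compound 4 (0.14 log units; within the scatter)). Among these compounds, no earlier pair isolated this change, and it now shows that 2-chloro-6-methoxyphenyl, with its added hydrogen-bond acceptor, can stand in place of 4-chlorophenyl on this aromatic carbon without a clear change in the amount of compound the cells tolerate. No measurement shown here explains this outcome.

This single pair cannot separate the part played by the chlorine's new place from that of the methoxy group, and it cannot show whether the result holds with the other saturated rings at the far end of the chain. Also open, as far as these compounds go, is how a pyridine ring in place of the phenyl ring, or an amine or carboxylic acid on that ring, would read here.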